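Replacing the Benzodioxin Amide Group in Compound 2

The source may hold more compounds than are shown below. What is called first, only, known or untested is meant among the compounds shown, and "the series" means these compounds.

Compound 2 `O=C(NC[C@@H]1C[C@@H]2C=C[C@@H]1C2)NS(=O)(=O)N1CCC(CCNC(=O)c2cccc3c2OCCO3)CC1` gives 40% in a functional assay on the whole organism (blood) with Rattus norvegicus as the target, with stated times of 24 h and 1 h, at a dose of 15 mg/kg by the intraperitoneal route (on this read-out lower numbers stand for a weaker effect and higher numbers for a stronger effect at the one dose given), the higher of the two numbers in hand; compound 1 `CC(=O)NCCC1CCN(S(=O)(=O)NC(=O)NC[C@@H]2C[C@@H]3C=C[C@@H]2C3)CC1` gives 25%. Going by the values given here, the single measured step, a number 15 percentage points higher from compound 1 to compound 2 (beyond the scatter), shows that replacing methyl on the carbonyl carbon with a ring group raised the read-out beyond the scatter. Compound 3 `Cn1cc(C(=O)NCCC2CCN(S(=O)(=O)NC(=O)NC[C@@H]3C[C@@H]4C=C[C@@H]3C4)CC2)c(=O)n(C)c1=O` differs from compound 2 in one place: a group of 10 heavy atoms (6 carbon, 2 nitrogen, 2 oxygen; one six-membered aromatic ring with 2 hetero atoms) in place of a group of 10 heavy atoms (8 carbon, 2 oxygen; one six-membered non-aromatic ring with 2 hetero atoms, one six-membered aromatic ring of carbon only), on a carbonyl carbon. Among the compounds with values here, no measured step compares two ring groups of equal size on that carbonyl carbon, so a change within the scatter is expected, no change at the digits printed from compound 2 to compound 3 (within the scatter). Compound 3 is therefore estimated at 40%, between 25% and 55%.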

Compound 3, a percentage reported as activity, at one dose (the size of the read-out at that dose, not a potency): 32%
For compound 3 the middle estimate is 8 percentage points above the measured one, and the stated range covers the measured number.
By their numbers in this assay, from the lowest: compounds 1, 3 and 2 (each within the scatter of the next, the first and the last beyond it).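

In this assay the carbonyl carbon accepts a single six-membered aromatic ring with 2 hetero atoms in place of the 2,3-dihydro-1,4-benzodioxin-5-yl group, with a number 8 percentage points lower from compound 2 to compound 3 (within the scatter). Set against the methyl group, the same ring gives a number 7 percentage points higher from compound 1 to compound 3 (within the scatter), so compound 3 is separated from neither neighbour, although compound 1 and compound 2 lie beyond the scatter of each other. No evidence given here bears on these results. On these data alone, whether a plain phenyl ring, a carboxylic acid or a longer chain on this carbonyl carbon would stand apart from compound 2 remains open.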